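Toward Compound 4: Swapping the Nitro Ring for Dichloro

The compounds below may be only part of what the source reports. "The series", "measured", "known", "first", "only" and "open" are said of these compounds alone.

In an ADME assay on MT4 cells (Homo sapiens) for cytotoxicity, read by MTT assay (a lower number here means that less compound is tolerated, a higher number that more compound is tolerated), the three measured compounds differ clearly. Compound 1 `O=C1c2ccccc2C(=O)N1CCOC(=S)N(C(=O)c1cccc([N+](=O)[O-])c1)c1ccc(Cl)cc1` gives 18000 nM, compound 3 `O=C1c2ccccc2C(=O)N1CCOC(=S)N(C(=O)c1ccc(Cl)c([N+](=O)[O-])c1)c1ccc(Cl)cc1` gives 48000 nM, and compound 2 `Cc1ccc(N(C(=O)c2cccc([N+](=O)[O-])c2)C(=S)OCCN2C(=O)c3ccccc3C2=O)cc1` gives 100000 nM, the highest of the three numbers; the nearest is compound 3, the furthest compound 1.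

Compound 4 `Cc1ccc(N(C(=O)c2ccc(Cl)c(Cl)c2)C(=S)OCCN2C(=O)c3ccccc3C2=O)cc1` is compound 2 changed in one place: 3,4-dichlorophenyl in place of 3-nitrophenyl on a carbonyl carbon. Among the measured compounds shown here, no measured pair exchanges a nitro group for chlorine directly. The closest guide is a 2.7-fold higher number from compound 1 to compound 3 (0.43 log units; beyond the scatter), where chlorine was added to the same ring, a modest move. That step suggests a small rise or no change beyond the scatter for compound 4 in this assay, so compound 4 is expected at about 110000 nM, within 45000 nM to 250000 nM, an estimated step of a 1.1-fold higher number from compound 2 to compound 4 (0.04 log units; within the scatter).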

Compound 4, half-maximal cytotoxic concentration: 17000 nM
Compound 4: middle estimate off by 6.5-fold (0.81 log units), on the high side, outside the stated range (below it).
By their numbers in this assay, from the lowest: compounds 4 and 1 (each within the scatter of the next); then compound 3; then compound 2.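

Exchanging 3-nitrophenyl for 3,4-dichlorophenyl on this carbonyl carbon gives a 5.9-fold lower number from compound 2 to compound 4 (0.77 log units; beyond the scatter) in this assay, so this position can move the number down as well as up. Chlorine added to the nitro-bearing ring went the other way, with a 2.7-fold higher number from compound 1 to compound 3 (0.43 log units; beyond the scatter) and the nitro group kept, so chlorine on this ring has no single direction across these compounds. No measurement shown explains the step. On these data alone, whether it follows the loss of the nitro group or the arrival of the two chlorines stays open. So does the effect of an amine or a carboxylic acid on this ring.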